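A few compounds are considered here, and "the series" means these few. Any claim that something is new, unique, unknown or untested is made for them only; others in the source may bear on it.

Compound 2, `CCc1cc(C(C)=O)c(O)cc1OCCCCCC(C)(C)C#N`: in an assay on isolated protein for inhibition of leukotriene B4 receptor 1 (Homo sapiens), tested at 10 uM (on this read-out higher numbers stand for more inhibition at the one concentration tested (going by the name of the read-out) and lower numbers for less inhibition), compound 2 gives 85%.
Compound 1, `CCCCc1cc(C(C)=O)c(O)cc1OCCCCC#N`: compound 1 gives 41%.
Compound 3, `CC(=O)c1cc(C(C)(C)C)c(OCCCCCC(C)(C)C#N)cc1O`: compound 3 gives 1%.

Among the compounds with values here, compound 2 stands highest of the three numbers; compound 1 lies below it beyond the scatter, and compound 3 lies furthest below, the one single-point step measured being a number 84 percentage points lower from compound 2 to compound 3 (beyond the scatter). That step alters the group on the aromatic carbon, not the chain end, so it does not bear directly on compound 4, `CCc1cc(C(C)=O)c(O)cc1OCCCCCCC(=O)O`, which differs from compound 2 by carboxymethyl in place of 1-cyano-1-methylethyl on a saturated chain carbon, five bonds along the chain from an oxygen on an aromatic ring. Within the data shown here, no measured step changes this chain end; compound 1 carries a plain nitrile on a shorter chain with other differences, so only its two values can be compared. A modest loss is therefore expected, with wide uncertainty: compound 4 is estimated at 60%, between 30% and 90%, an expected step of a number 25 percentage points lower from compound 2 to compound 4 (beyond the scatter).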

Compound 4, a percentage reported as inhibition, at one concentration (the size of the read-out at that concentration, not a potency): 87%
For compound 4 the middle estimate is 27 percentage points below the measured one; measured number inside the range.
By their numbers in this assay, from the lowest: compound 3; then compound 1; then compounds 2 and 4 (each within the scatter of the next).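

In this assay, the change at this chain end gives a number 2 percentage points higher from compound 2 to compound 4 (within the scatter), so on this pair the nitrile and its two methyl groups are not needed to keep the inhibition at the one concentration tested. The end group can also gain a hydrogen-bond donor, which carboxymethyl has and 1-cyano-1-methylethyl lacks, with no change beyond the scatter. No measurement here explains why the two end groups read alike. Still open, going by these compounds, is whether an amine or a primary amide at this chain end would do the same, and whether carboxymethyl holds up on a longer chain or with tert-butyl in place of ethyl.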